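A few compounds are considered here, and "the series" means these few. Any claim that something is new, unique, unknown or untested is made for them only; others in the source may bear on it.

Measured compounds:
compound 1 `O=C(O)CCc1ccc(NCc2ccc(-c3ccccc3)cc2)cc1`, 251 nM
compound 2 `O=C(O)CCc1ccc(NCc2ccc(Cl)s2)cc1`, 2000 nM
compound 3 `O=C(O)CCc1ccc(NCc2ccccc2Cl)cc1`, 3980 nM

Three compounds share the same core and differ only in the group carried on the benzylic amine. In a functional assay for agonist activity at Free fatty acid receptor 1 (Homo sapiens) (a lower number here means that less compound is needed, a higher number that more compound is needed for the effect), compound 1 gives 251 nM, compound 2 gives 2000 nM and compound 3 gives 3980 nM. Compound 3 thus stands at the highest of the three numbers in this assay; its nearest neighbour is compound 2, whose number is within the scatter of it, while compound 1 lies well beyond the scatter at a much lower number.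

Compound 4 `O=C(O)CCc1ccc(NCc2ccccc2)cc1` has not yet been measured. It differs from compound 3 in one place: hydrogen in place of chloro on an aromatic carbon, on an aromatic carbon of a six-membered aromatic ring of carbon only, ortho to a large group. Among the compounds with values here, no measured pair in this set shows the same change, so the size of the step can only be guessed. The three measured compounds suggest that the group on the benzylic amine matters, and that a smaller group goes with a higher number, so a modest rise in this assay is expected for compound 4, and the step from compound 3 to compound 4 is estimated as a 1.3-fold higher number from compound 3 to compound 4 (0.10 log units; within the scatter), likely within the scatter. Compound 4 is expected to give about 5000 nM in this assay, with a range from 1500 nM to 16000 nM.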

Compound 4, half-maximal effective concentration: 7940 nM
Estimate against measurement, compound 4: 1.6-fold (0.20 log units) below; measured number inside the range.
By their numbers in this assay, from the lowest: compound 1; then compounds 2, 3 and 4 (each within the scatter of the next, the first and the last beyond it).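

In this assay, within the data shown here, hydrogen in place of chloro on an aromatic carbon, ortho to a large group, is the first step read at this position. It amounts to a 2.0-fold higher number from compound 3 to compound 4 (0.30 log units; within the scatter) and so does not separate the chloro of compound 3 from the hydrogen of compound 4 in this assay. Compound 4 also gives the other two groups a direct reference, with phenyl in place of 5-chlorothiophen-2-yl on a saturated chain carbon bound to a nitrogen on an aromatic ring giving a 4.0-fold higher number from compound 2 to compound 4 (0.60 log units; beyond the scatter) and the removal of the phenyl giving a 32-fold higher number from compound 1 to compound 4 (1.50 log units; beyond the scatter) as the large step of the set.

Going by these compounds, whether a fluoro or a methoxy in place of the chloro would read any differently from hydrogen stays open, as does whether a phenoxy in place of the phenyl of compound 1 would keep the low number of that compound. The compounds shown come with no further measurement that could explain any of these steps.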